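Compound 1 to compound 4: swapping the benzyl group

This account rests on a few compounds, and the source may have more. Where it says the series, first, only, none or still open, it means among the compounds named here.

In a functional assay on MGC-803 cells (Homo sapiens) for antiproliferative activity, read by MTT assay, with a stated time of 48 h (on this read-out lower numbers stand for stronger inhibition and higher numbers for weaker inhibition), compound 1 `COc1ccc(CN(C(=O)CSc2nc3ccccc3s2)c2cc(OC)c(OC)c(OC)c2)cc1O` gives 35 nM, the lowest number of the three measured. Compound 2 `COc1ccc(CN(C(=O)CSc2nc3cc(Cl)ccc3s2)c2cc(OC)c(OC)c(OC)c2)cc1O` gives 85 nM and compound 3 `COc1ccc(CN(C(=O)CSc2nc3c(C)cccc3s2)c2cc(OC)c(OC)c(OC)c2)cc1O` gives 493 nM.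

Compound 4 `COc1cc(N(Cc2ccc(Cl)cc2)C(=O)CSc2nc3ccccc3s2)cc(OC)c1OC` departs from compound 1 at a single place: 4-chlorophenyl in place of 3-hydroxy-4-methoxyphenyl on a saturated chain carbon bound to an amide-type nitrogen. In words, 4-chlorophenyl stands in place of 3-hydroxy-4-methoxyphenyl on a saturated chain carbon bound to an amide-type nitrogen.

Among the compounds with values here, all three measured compounds carry the 3-hydroxy-4-methoxybenzyl group, so no measured step tests this change directly. The available steps bear on it only indirectly, as a guide to how far single changes move the number in this small set. Chloro in place of hydrogen gave a 2.4-fold higher number from compound 1 to compound 2 (0.39 log units; beyond the scatter), a modest step. Methyl in place of hydrogen gave a 14-fold higher number from compound 1 to compound 3 (1.15 log units; beyond the scatter), a large one. Neither change lowered the number.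

Compound 4 replaces a whole group, not one hydrogen, so a large upward step is expected in this assay, of about the size of the methyl step a 14-fold higher number from compound 1 to compound 3 (1.15 log units; beyond the scatter) or somewhat larger, though with wide uncertainty. The estimated step is a 20-fold higher number from compound 1 to compound 4 (1.30 log units; beyond the scatter). The expected value for compound 4 is 700 nM, with an estimated range of 150 nM to 3500 nM.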

Compound 4, half-maximal inhibitory concentration: > 80000 nM
Compound 4 ended at the assay's limit; the forecaster's own chance of this, stated with the estimate: 5%; at least 110-fold (2.05 log units) between middle value and limit.
By their numbers in this assay, from the lowest: compound 1; then compound 2; then compound 3. At a limit, above all of these: compound 4.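

In this assay compound 4 gives > 80000 nM, which is a limit of the assay and not a number: the limit of > 80000 nM in this assay, at which 1 of the 4 values shown sits.

On a saturated chain carbon bound to an amide-type nitrogen, the change to 4-chlorophenyl gives an at least 2200-fold higher number from compound 1 to compound 4 (3.35 log units; beyond the scatter), a bound rather than a measured size, and it exceeds both the chloro step, a 2.4-fold higher number from compound 1 to compound 2 (0.39 log units; beyond the scatter), and the methyl step, a 14-fold higher number from compound 1 to compound 3 (1.15 log units; beyond the scatter). The earlier compounds shown here all kept the 3-hydroxy-4-methoxyphenyl group and stayed within the measurable range, whereas compound 4 shows that exchanging this group for 4-chlorophenyl leaves that range.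

Compound 4 loses the hydroxy group and the methoxy group and gains the chloro group in one step, so the compounds shown do not tell which of these changes accounts for the loss of activity, or whether any one alone would do so. On these data alone, a phenyl ring keeping only the hydroxy group or only the methoxy group, or carrying an amine or a carboxylic acid, remains open, as does the effect of the same exchange on the cores of compound 2 and compound 3.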